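From 3,4-dimethoxyphenyl to 2-methoxyphenyl: an expected step

The source may report more compounds than this note shows. Statements on the series, on what has been measured and on what is new or still open speak of the compounds shown alone.

Of the compounds shown here, three sharing a common core have been tested in a functional assay on MIA PaCa-2 cells (Homo sapiens) for inhibition, read by MTT assay, with a stated time of 72 h; a lower number here means a stronger inhibitor of growth, a higher number a weaker inhibitor of growth. Compound 1 `O=S(=O)(NCCNCc1cccc2ccccc12)c1cc(C(F)(F)F)cc(C(F)(F)F)c1` gives 26000 nM. Compound 3 `O=S(=O)(NCCCCCCNCc1ccc(Br)cc1)c1c(Cl)cccc1Cl` gives 14700 nM. Compound 2 `COc1ccc(CNCCCNS(=O)(=O)c2cc(C(F)(F)F)cc(C(F)(F)F)c2)cc1OC` gives 2800 nM, the lowest of the three numbers; compound 3 stands above it by a gap beyond the usual scatter, and compound 1 further still. From this standing the account moves to compound 4 `COc1ccccc1CNCCCNS(=O)(=O)c1cc(C(F)(F)F)cc(C(F)(F)F)c1`, which has not yet been measured. It differs from compound 2 in a single respect: 2-methoxyphenyl in place of 3,4-dimethoxyphenyl on a saturated chain carbon bound to an amine nitrogen. Within the data shown here, no pair of measured compounds isolates a change of this kind, so no measured step can guide the expectation. A step of modest size is expected, leaning toward a weaker inhibitor of growth, because compound 2 at 2800 nM is the sole anchor and the two other compounds sit well above it. The expected step is a 1.8-fold higher number from compound 2 to compound 4 (0.25 log units; within the scatter). For compound 4 the estimate is 5000 nM, with a range from 1500 nM to 16000 nM.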

Compound 4, concentration for 50% growth inhibition: 3100 nM
For compound 4 the middle estimate is 1.6-fold (0.21 log units) above the measured one; the range from low to high includes it.
By their numbers in this assay, from the lowest: compounds 2 and 4 (each within the scatter of the next); then compounds 3 and 1 (each within the scatter of the next).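

In this assay, replacing 3,4-dimethoxyphenyl with 2-methoxyphenyl on a saturated chain carbon bound to an amine nitrogen gives a 1.1-fold higher number from compound 2 to compound 4 (0.04 log units; within the scatter), so this assay does not separate the two compounds. The earlier compounds shown here included no pair isolating a change at this place, and this pair now shows that, on this core, the 3,4-dimethoxyphenyl group is not needed for a number at the level of compound 2. No independent evidence bears on why the two numbers match.

The compounds shown leave open whether unsubstituted phenyl, 4-methoxyphenyl or 4-hydroxyphenyl at this place would also stand with compound 2 and compound 4. Also open, on these data alone, is whether the exchange would read the same way on a longer chain, such as a hexyl linker.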